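The source may hold more compounds than are shown below. What is called first, only, known or untested is meant among the compounds shown, and "the series" means these compounds.

Compound 1 `COc1cc2c(Oc3ccc(NC(=O)c4cc(-c5ccc(F)cc5)ccn4)cc3F)ccnc2cc1OCCCN1CCN(C)CC1`: in a functional assay on HT-29 cells (Homo sapiens) for cytotoxicity, read by MTT assay, with a stated time of 72 h (on this read-out lower numbers stand for stronger inhibition and higher numbers for weaker inhibition), compound 1 gives 1460 nM.
Compound 2 `COc1cc2c(Oc3ccc(NC(=O)c4cc(-c5ccc(C)cc5)ccn4)cc3F)ccnc2cc1OCCCN1CCCC1`: in this assay compound 2 gives 350 nM.

Compound 2 holds the lower of the two numbers; compound 1 sits at a higher number, and that gap lies beyond the usual scatter. Compound 1 and compound 2 differ in more than one place, so nothing can be said about any single change between them.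

Compound 3 `COc1ccc(-c2ccnc(C(=O)Nc3ccc(Oc4ccnc5cc(OCCCN6CCCC6)c(OC)cc45)c(F)c3)c2)cc1` has not been measured. It differs from compound 2 in one place: methoxy in place of methyl on an aromatic carbon, para to a large group. Among the compounds with values here, no pair of measured compounds shows this change on its own, so there is nothing to lean on. With that, the expectation is for little movement in this assay, none beyond the scatter, in either direction. For compound 3 the estimate is 400 nM, between 150 nM and 1100 nM. That estimate means a step of a 1.1-fold higher number from compound 2 to compound 3 (0.06 log units; within the scatter), expected to stay within the scatter.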

Compound 3, half-maximal inhibitory concentration: 350 nM
Compound 3: middle estimate off by 1.1-fold (0.06 log units), on the high side; the range from low to high includes it.
By their numbers in this assay, from the lowest: compounds 2 and 3 (each within the scatter of the next); then compound 1.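

In this assay, exchanging methyl for methoxy on an aromatic carbon, para to a large group, gives no change at the digits printed from compound 2 to compound 3 (within the scatter). Within the data shown here, this is the first comparison here that isolates a single change, since compound 1 and compound 2 differ in more than one place: going from 4-methylphenyl to 4-methoxyphenyl adds one oxygen atom and a hydrogen-bond acceptor at this position without a change beyond the scatter. Nothing measured here explains why the two groups read alike.

On these data alone, it remains open whether this position would accept very different groups, such as an amine, a carboxylic acid or a longer chain like ethoxy, equally well. The gap between compound 1 and compound 2 also still cannot be assigned to either place where they differ.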